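Chain extension of the ester side arm: compound 2 to compound 3

The source may report more compounds than this note shows. Statements on the series, on what has been measured and on what is new or still open speak of the compounds shown alone.

Measured in an ADME assay on HepG2 2.2.15 cells (Homo sapiens) for cytotoxicity; a lower number here means that less compound is tolerated, a higher number that more compound is tolerated
compound 1 `O=C(OCCc1c(-c2ccccc2Cl)c2cc(Cl)ccc2[nH]c1=O)c1ccco1` gives 98000 nM
compound 2 `O=C(COc1ccccc1)OCCc1c(-c2ccccc2Cl)c2cc(Cl)ccc2[nH]c1=O` gives 81000 nM

With only these two values in this assay, compound 2 at 81000 nM stands within the scatter of compound 1 and the pair gives no real spread. The next compound to be measured is compound 3 `O=C(CCOc1ccccc1)OCCc1c(-c2ccccc2Cl)c2cc(Cl)ccc2[nH]c1=O` and it carries phenoxymethyl in place of phenoxy on a saturated chain carbon bound to a carbonyl carbon on the same shared core. The same difference reads as phenoxymethyl to 2-phenoxyethyl.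

For the measured compounds named here, no measured step covers this exact change. The closest evidence is a 1.2-fold lower number from compound 1 to compound 2 (0.08 log units; within the scatter) in which a different group on the same carbonyl was exchanged and the number stayed within the scatter. That single step is thin support, but it gives no reason to expect a real shift in either direction. The expected change is a 1.1-fold lower number from compound 2 to compound 3 (0.03 log units; within the scatter) and no step beyond the scatter is expected. The estimate for compound 3 is 75000 nM with an expected range from 40000 nM to 130000 nM in this assay once measured.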

Compound 3, half-maximal cytotoxic concentration: 46000 nM
Beside the measured number, compound 3's estimate is 1.6-fold (0.21 log units) above it; measured number inside the range.
By their numbers in this assay, from the lowest: compounds 3, 2 and 1 (each within the scatter of the next, the first and the last beyond it).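

In this assay, 2-phenoxyethyl in place of phenoxymethyl on the carbonyl carbon gives a 1.8-fold lower number from compound 2 to compound 3 (0.25 log units; within the scatter) and so does not separate the two compounds, even with the chain extended. Set against the furan-2-yl ester, the same 2-phenoxyethyl group gives a 2.1-fold lower number from compound 1 to compound 3 (0.33 log units; beyond the scatter) and this is the only step in the series that passes the scatter, though modestly. The group on this carbonyl can therefore move the number in this assay, but only across the full span from furan-2-yl to 2-phenoxyethyl, with the phenoxymethyl compound lying within the scatter of both neighbours.

Open, from the compounds shown here alone, is whether a longer chain such as 3-phenoxypropyl would continue in the same direction or whether the series levels off at 2-phenoxyethyl. Also open, going by these compounds, is whether the phenyl ring at the end of the chain matters to the number, which a chain ending in an amine or a carboxylic acid would test. Nothing at hand bears on what lies behind these steps.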